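The source may report more compounds than this note shows. Statements on the series, on what has been measured and on what is new or still open speak of the compounds shown alone.

The measured compounds:
compound 1, `COc1ccc(/C(=C(/CCN)c2ccccc2)c2ccccc2)cc1`, gives 16900 nM in a functional assay on MCF7 cells (Homo sapiens) for cytotoxicity, read by MTT assay, with a stated time of 72 h; on this read-out higher numbers stand for weaker inhibition and lower numbers for stronger inhibition.
compound 2, `COc1ccc(/C(=C(/CCNC(=O)N2CCCCC2)c2ccccc2)c2ccccc2)cc1`, gives > 50000 nM in this assay, which is a limit of the assay and not a number.

Compound 2 thus stands at the weak end of the numbers shown: in this assay it sits at the limit of > 50000 nM in this assay, at which 1 of the 2 values shown sits. The step of an at least 2.9-fold higher number from compound 1 to compound 2 (0.47 log units; beyond the scatter) shows that placing the (piperidin-1-yl)carbonyl on the amine nitrogen weakened the inhibition.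

Compound 3, `COc1ccc(/C(=C(/CCNC(=O)N2CCCC2)c2ccccc2)c2ccccc2)cc1`, differs from compound 2 in one place: pyrrolidin-1-yl in place of piperidin-1-yl on a carbonyl carbon. A five-membered saturated ring takes the place of a six-membered one on the carbonyl carbon. Among the compounds with values here, no measured step bears directly on this change; the only measured step, an at least 2.9-fold higher number from compound 1 to compound 2 (0.47 log units; beyond the scatter), concerns a different change, the attachment of the whole carbamoyl piece. With the nearest neighbour, compound 2, already at a limit, the step that the limit leaves unreadable from compound 2 to compound 3 is expected to be none beyond the scatter. Compound 3 is therefore expected to give about 60000 nM, within a range of 25000 nM to 150000 nM, and most likely to be reported again only as a limit.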

Compound 3, half-maximal inhibitory concentration: > 50000 nM
Compound 3 was reported as a limit (the forecaster's own chance of this, stated with the estimate: 70%); the middle value lies beyond the limit too.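

Compound 3 shows that the loss of inhibition seen with compound 2 does not depend on one particular ring: with pyrrolidin-1-yl on the carbonyl carbon, the amine nitrogen of compound 1 again carries a ring-bearing carbonyl group, and the result is an at least 2.9-fold higher number from compound 1 to compound 3 (0.47 log units; beyond the scatter). Two different rings at this nitrogen now end in the same place in this assay, and the number of compounds at the limit has grown: the limit of > 50000 nM in this assay, at which 2 of the 3 values shown sit.

The step from compound 2 to compound 3 cannot be read, as both values are limits, so the change from a six-membered to a five-membered ring may or may not matter below that limit.

The compounds shown leave open how much of the carbonyl-bearing piece on the nitrogen is enough to lose the measurable value of 16900 nM that compound 1 gives, for instance whether a small acetyl group on the amine nitrogen would still give a readable number. They also leave open whether a ring with a second hetero atom, such as morpholin-4-yl on the carbonyl carbon, would bring the value back within the range of the assay.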